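Working notes: from compound 2 to compound 3

The compounds below may be only part of what the source reports. "The series", "measured", "known", "first", "only" and "open" are said of these compounds alone.

Measured so far in a functional assay on ASPC1 cells (Homo sapiens) for cytotoxicity; a higher number here means a weaker inhibitor, a lower number a stronger inhibitor
- compound 1 `O=C(CCCCCCC(=O)Nc1nc2ccccc2s1)NO` gives 5.69 ug/mL
- compound 2 `Cc1ccc2nc(NC(=O)CCCCC(=O)NO)sc2c1` gives 13.3 ug/mL

Compound 2 at 13.3 ug/mL holds the higher of the two numbers, and compound 1 lies below it by more than the usual scatter. Compound 3 `O=C(CCCCC(=O)Nc1nc2ccccc2s1)NO` carries hydrogen in place of methyl on an aromatic carbon of compound 2 (hydrogen in place of methyl on an aromatic carbon) and nothing else changes. Among the measured compounds shown here, no measured pair isolates such a change, so the data give no direct size for it. In this assay a small step to a lower number is expected, probably not beyond the scatter. The expected step is a 1.3-fold lower number from compound 2 to compound 3 (0.12 log units; within the scatter). For compound 3 the estimated value is 10 ug/mL with an expected range from 4.5 ug/mL to 22 ug/mL.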

Compound 3, half-maximal inhibitory concentration: 10.2 ug/mL
Beside the measured number, compound 3's estimate is 1.0-fold (0.01 log units) below it; the range from low to high includes it.
By their numbers in this assay, from the lowest: compounds 1, 3 and 2 (each within the scatter of the next, the first and the last beyond it).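

In this assay, the aromatic carbon of compound 2 gives the first single-change reading: hydrogen in place of methyl amounts to a 1.3-fold lower number from compound 2 to compound 3 (0.12 log units; within the scatter), so the methyl shows no effect here that stands clear of the scatter. The chain now has its own reading as well, since hydroxycarbamoyl in place of 2-(hydroxycarbamoyl)ethyl on a saturated chain carbon, four bonds along the chain from a carbonyl carbon, amounts to a 1.8-fold higher number from compound 1 to compound 3 (0.25 log units; within the scatter). Compound 3 thus splits the gap between the two earlier compounds, which differ in two places, into two single changes, each within the scatter on its own.

As far as these compounds go, whether a methoxy group, a chlorine or an amine on this aromatic carbon, or a longer chain, would move the number beyond the scatter remains open. Nothing available explains either step.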